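The source may hold more compounds than are shown below. What is called first, only, known or untested is meant among the compounds shown, and "the series" means these compounds.

Measured so far: compound 1 `Nc1c([S+]([O-])CCCF)sc2nc(-c3cccs3)cc(-c3ccccc3)c12`, compound 2 `CCCC[S+]([O-])c1sc2nc(-c3ncco3)cc(-c3ccccc3)c2c1N`, compound 3 `CCOC(=O)c1sc2nc(-c3cccs3)cc(-c3ccccc3)c2c1N`.

In an assay for inhibition of 15-hydroxyprostaglandin dehydrogenase [NAD(+)] (Homo sapiens), read by fluorescence, with a stated time of 15 min, in the presence of a further agent that is not named here (on this read-out higher numbers stand for weaker inhibition and lower numbers for stronger inhibition), compound 1 gives 6.1 nM. Compound 2 gives 1.4 nM in this assay. Compound 3 reaches only a limit of this assay, > 7500 nM. On the numbers shown, compound 3 thus stands at the limit of > 7500 nM in this assay, at which 1 of the 3 values shown sits, while compound 1 and compound 2 give numbers inside the measurable range. Within the data shown here, the one measured step that ends at compound 3, an at least 1200-fold higher number from compound 1 to compound 3 (3.08 log units; beyond the scatter), is large and beyond the scatter.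

Compound 4 `CCCNC(=O)c1sc2nc(-c3cccs3)cc(-c3ccccc3)c2c1N` differs from compound 3 by propylamino in place of ethoxy on a carbonyl carbon. No measured step concerns an exchange of this kind; the only step shown concerns a different change and gives no direction for this one. The step that the limit leaves unreadable from compound 3 to compound 4 is therefore expected to stay within the scatter. The estimate for compound 4 is 8000 nM, within 2000 nM to 30000 nM.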

Compound 4, half-maximal inhibitory concentration: > 7500 nM
Compound 4: no number, only a limit (the forecaster's own chance of this, stated with the estimate: 60%); the middle value lies beyond the limit too.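

In this assay compound 4 gives only a limit, > 7500 nM, and is the second compound there: the limit of > 7500 nM in this assay, at which 2 of the 4 values shown sit.

On the aromatic carbon, the propylcarbamoyl group in place of the group of compound 1 gives an at least 1200-fold higher number from compound 1 to compound 4 (3.08 log units; beyond the scatter), so the large loss is no longer tied to ethoxycarbonyl alone. The step between the two carbonyl compounds cannot be read, which leaves ethoxy and propylamino unordered.

Still open, on these data alone, is whether any carbonyl-linked group at this place returns a measurable number. A carboxylic acid or a longer amine chain on the carbonyl carbon would test this.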